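This account rests on a few compounds, and the source may have more. Where it says the series, first, only, none or still open, it means among the compounds named here.

Working notes on the series. The shared core is that of compound 1 `COc1cccc(COc2ccc3cc(C(=O)/C=C/c4cc(OC)ccc4OC)c(=O)oc3c2)c1`; the compounds differ in the group on the double-bonded chain carbon and in the substituent on the core. In a functional assay on MCF7 cells (Homo sapiens) for cytotoxicity, read by MTT assay, with a stated time of 72 h (on this read-out higher numbers stand for weaker inhibition and lower numbers for stronger inhibition), compound 1 gives > 100000 nM, which is a limit of the assay and not a number. Of the three values recorded, (the limit of > 100000 nM in this assay, at which 1 of the 3 values shown sits). Compound 2 `COc1cc(/C=C/C(=O)c2cc3ccc(O)cc3oc2=O)cc(OC)c1OC` gives 8800 nM in this assay. Compound 3 `COc1cc(/C=C/C(=O)c2cc3cc(OCc4ccccc4)ccc3oc2=O)cc(OC)c1OC` gives 26500 nM in this assay. Going by the values given here, compound 1 stands apart in that its value is only a limit, so no step between it and compound 2 or compound 3 can be sized.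

Compound 4 `COc1cccc(COc2ccc3cc(C(=O)/C=C/c4ccc(C)cc4)c(=O)oc3c2)c1` is not yet measured. It differs from compound 1 in one place: 4-methylphenyl in place of 2,5-dimethoxyphenyl on a double-bonded chain carbon bound to a double-bonded chain carbon. Compound 2 and compound 3, which gave numbers, differ from compound 4 in more than this one place and so set no direct expectation. The starting point is a limit, so the expected step is an at least 1.6-fold lower number from compound 1 to compound 4 (0.22 log units; that floor lies within the scatter), taken as none beyond the scatter or at most a modest gain. In this assay compound 4 is estimated at 60000 nM, expected within 15000 nM to 200000 nM, with a fair chance that only a limit is again reported.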

Compound 4, half-maximal inhibitory concentration: > 50000 nM
Compound 4: a limit, no number; the forecaster's own chance of this, stated with the estimate: 50%; the middle value does not contradict the limit.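

The step from compound 1 to compound 4 cannot be read: in this assay both compounds give only a limit of the assay and not a number. The compounds shown leave open whether 4-methylphenyl in place of 2,5-dimethoxyphenyl on the shared core changes the read-out at all in this assay.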